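The compounds below may be only part of what the source reports. "The series", "measured", "known", "first", "only" and "open" are said of these compounds alone.

In a functional assay (aorta) with Rattus norvegicus as the target (a lower number here means that less compound is needed, a higher number that more compound is needed for the effect), compound 2 `CCNC1=NS(=O)(=O)c2cc(F)ccc2N1` gives > 300 uM, which is a limit of the assay and not a number. This puts compound 2 at the limit of > 300 uM in this assay, at which 2 of the 3 values shown sit. Compound 1 `CNC1=NS(=O)(=O)c2cc(F)ccc2N1` shows the same kind of limit, > 300 uM. Compound 3 `CCC(C)NC1=NS(=O)(=O)c2cc(F)ccc2N1`, with sec-butyl on the amine nitrogen, gives a true number, 39.2 uM.

Compound 4 `CC(C)C(C)NC1=NS(=O)(=O)c2cc(F)ccc2N1` differs from compound 2 as follows: isopropyl in place of hydrogen on a saturated chain carbon bound to an amine nitrogen and a saturated chain carbon. Cut one bond further out, this turns ethyl into 1,2-dimethylpropyl.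

The closest measured change puts ethyl in place of hydrogen on the same kind of carbon, and it is an at least 7.6-fold lower number from compound 2 to compound 3 (0.88 log units; beyond the scatter). Compound 1 gives a similar picture, with an at least 7.6-fold lower number from compound 1 to compound 3 (0.88 log units; beyond the scatter). The smaller change is a step that the two limits leave unreadable from compound 1 to compound 2, so it offers no guidance.

On the strength of the step to compound 3, a move in the same direction is expected here. In this assay, the expected step is an at least 16-fold lower number from compound 2 to compound 4 (1.22 log units; beyond the scatter), which would be a lower number beyond the scatter. For compound 4 the estimated value is 18 uM, with an expected range from 5 uM to 70 uM.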

Compound 4, concentration for half-maximal effect: 26.4 uM
Beside the measured number, compound 4's estimate is 1.5-fold (0.17 log units) below it; low and high end bracket the measured number.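

In this assay, the larger branched 1,2-dimethylpropyl group on the amine nitrogen also gives a true number rather than a limit, with both small-chain compounds as reference points (an at least 11-fold lower number from compound 2 to compound 4 (1.05 log units; beyond the scatter); an at least 11-fold lower number from compound 1 to compound 4 (1.05 log units; beyond the scatter)). The extra methyl on a saturated chain carbon bound to two saturated chain carbons, which separates sec-butyl from 1,2-dimethylpropyl, brings no change that can be told from scatter (a 1.5-fold lower number from compound 3 to compound 4 (0.17 log units; within the scatter)). So this position accepts more branching, but here that added branch buys nothing further.

As far as these compounds go, whether a longer chain such as n-pentyl, or a ring such as cyclohexyl, on the amine nitrogen would lower the number further stays open. From the compounds shown here alone, the full size of the large steps also stays open because the starting points are limits, not numbers: the limit of > 300 uM in this assay, at which 2 of the 4 values shown sit.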